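Hydroxypropyl for methyl on the core nitrogen of compound 1

The compounds below may be only part of what the source reports. "The series", "measured", "known", "first", "only" and "open" are said of these compounds alone.

Compound 1 `Cn1c(Cc2nn(C)c(=O)c3ccccc23)nnc1SCCCCCCCC(=O)Nc1ccc(Cl)cc1Cl` — 3900 nM
Compound 2 `Cn1nc(Cc2nnc(SCC(=O)Nc3ccc(Cl)cc3Cl)n2CCC(=O)O)c2ccccc2c1=O` — > 30000 nM

Of the compounds shown here, two have been measured in an assay on 32D cells for inhibition of interleukin-15 (Mus musculus), read by resazurin assay, with stated times of 30 min and 2.5 days, in the presence of a further agent that is not named here; a higher number here means a weaker inhibitor, a lower number a stronger inhibitor. Within the data shown here, compound 1 gives 3900 nM, the only actual number in the set. Among the measured compounds shown here, for compound 2 the assay reports only a limit, > 30000 nM, and that is the one value at the limit of > 30000 nM in this assay, at which 1 of the 2 values shown sits. Compound 2 differs from compound 1 in more than one place, so the gap between them is not read as a single step.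

Compound 3 `Cn1nc(Cc2nnc(SCCCCCCCC(=O)Nc3ccc(Cl)cc3Cl)n2CCCO)c2ccccc2c1=O` differs from compound 1 by a single change: 2-hydroxyethyl in place of hydrogen on a saturated chain carbon bound to an aromatic nitrogen. For the measured compounds named here, no measured pair shows the effect of such a change here, and the added group is small and uncharged. Compound 3 is therefore expected to sit close to compound 1, with the step from compound 1 to compound 3 estimated at a 1.0-fold higher number from compound 1 to compound 3 (0.01 log units; within the scatter), no more than the scatter in either direction. The estimate for compound 3 is 4000 nM, with a range from 1500 nM to 12000 nM.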

Compound 3, half-maximal inhibitory concentration: > 30000 nM
Compound 3 was reported as a limit (the forecaster's own chance of this, stated with the estimate: 10%); at least 7.5-fold (0.87 log units) between middle value and limit.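

Among these compounds, the change of methyl to 3-hydroxypropyl, on a saturated chain carbon bound to an aromatic nitrogen, is the first single change that can be read in this set, and it gives an at least 7.6-fold higher number from compound 1 to compound 3 (0.88 log units; beyond the scatter) in this assay. Compound 3 gives > 30000 nM, which is a limit of the assay and not a number, so the step has a lower bound but no full size. This position on the core is therefore sensitive to this change, but how far the weakening goes cannot be read, as the value stands at a limit shared within the set: the limit of > 30000 nM in this assay, at which 2 of the 3 values shown sit.

The compounds shown do not separate the longer chain from its terminal hydroxyl, and a plain propyl group at this position would speak to that. As far as these compounds go, how an ethyl group, a 3-methoxypropyl group or a 3-aminopropyl group would read here also remains open.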